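Compound 4 Without the Isobutyl of Compound 2

The compounds below may be only part of what the source reports. "The series", "measured", "known", "first", "only" and "open" are said of these compounds alone.

Compound 2 `CCOC(=O)c1c(-c2cccc(OCC(C)C)c2)[nH]c2cc(OC)ccc2c1=O` in an ADME assay on Raji cells (Homo sapiens) for cytotoxicity, read by luminescence, with a stated time of 72 h (a higher number here means that more compound is needed for the effect, a lower number that less compound is needed), gives only a limit, > 21500 nM. Compound 1 `CCOC(=O)c1c(-c2cccc(C)c2)[nH]c2cc(OC)ccc2c1=O` in this assay likewise gives a limit, > 21500 nM. Compound 3 `CCOC(=O)c1c(-c2cccc([N+](=O)[O-])c2)[nH]c2cc(OC)ccc2c1=O` in this assay also gives a limit, > 21500 nM. All three values sit at the limit (the limit of > 21500 nM in this assay, at which 3 of the 3 values shown sit). The steps a step that the two limits leave unreadable from compound 1 to compound 2, a step that the two limits leave unreadable from compound 1 to compound 3 and a step that the two limits leave unreadable from compound 2 to compound 3 therefore have no readable size. Compound 4 `CCOC(=O)c1c(-c2cccc(O)c2)[nH]c2cc(OC)ccc2c1=O` differs from compound 2 by hydrogen in place of isobutyl on an oxygen on an aromatic ring. The three measured steps all concern exchanges on an aromatic carbon and give neither size nor direction, so nothing measured speaks for a readable change here. The step that the limit leaves unreadable from compound 2 to compound 4 is expected to be none beyond the scatter. Compound 4 is estimated at 30000 nM, ranging from 8000 nM to 120000 nM.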

Compound 4, half-maximal effective concentration: > 21500 nM
Compound 4 ended at the assay's limit; the forecaster's own chance of this, stated with the estimate: 85%; the middle value lies beyond the limit too.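

The steps linking compound 4 with compound 1, compound 2 and compound 3 cannot be read, as all four compounds stand at the same limit: the limit of > 21500 nM in this assay, at which 4 of the 4 values shown sit.

On these data alone, whether any of these exchanges on the shared core changes the result in this assay stays open.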